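Chain lengthening from compound 3 to compound 4

A few compounds are considered here, and "the series" means these few. Any claim that something is new, unique, unknown or untested is made for them only; others in the source may bear on it.

In a functional assay on HeLa cells (Homo sapiens) for cytotoxicity, read by MTT assay, with a stated time of 72 h (a lower number here means a stronger inhibitor, a higher number a weaker inhibitor), compound 3 (`C#C[C@H](O)/C=C/CCCCC/C=C\CCCC/C=C\CCCCCCCCC/C=C/[C@@H](O)C#C`) gives 260 nM, level with compound 2 (`C#C[C@H](O)/C=C/CCCCCCCCC/C=C\CCCCCCCCCCC/C=C/[C@@H](O)C#C`) at 260 nM. Compound 1 (`C#C[C@H](O)/C=C/CCCCCCCCC/C=C\CCCCCCCCC/C=C/[C@@H](O)C#C`) gives 500 nM, within the scatter of both. Compound 4 (`C#C[C@H](O)/C=C/CCCCCCC/C=C\CCCC/C=C\CCCCCCCCC/C=C/[C@@H](O)C#C`) differs from compound 3 by one change: a group of 8 heavy atoms (7 carbon, 1 oxygen; no ring) in place of a group of 6 heavy atoms (5 carbon, 1 oxygen; no ring), on a saturated chain carbon, five bonds along the chain from a double-bonded chain carbon. Among the compounds with values here, the only measured step of this kind is a 1.9-fold lower number from compound 1 to compound 2 (0.28 log units; within the scatter). It makes the same exchange at a different place, on a saturated chain carbon, nine bonds along the chain from a double-bonded chain carbon, so the evidence is a single, small step. The expected size is a 1.2-fold lower number from compound 3 to compound 4 (0.09 log units; within the scatter), and no shift beyond the scatter is expected in this assay. Compound 4 is estimated at 210 nM, with an expected range of 100 nM to 450 nM.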

Compound 4, half-maximal inhibitory concentration: 100 nM
The estimate for compound 4 lay 2.1-fold (0.32 log units) above the measured number, and the stated range covers the measured number.
By their numbers in this assay, from the lowest: compound 4; then compounds 2, 3 and 1 (each within the scatter of the next).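

Within the data shown here, the exchange of the group of 6 heavy atoms for the group of 8 heavy atoms, on a saturated chain carbon, five bonds along the chain from a double-bonded chain carbon, gives in this assay a 2.6-fold lower number from compound 3 to compound 4 (0.41 log units; beyond the scatter), the only step of this kind beyond the scatter. The direction is the same on both cores, and the sizes of the two steps cannot be told apart: the same change on two cores in this assay, a 1.9-fold lower number (0.28 log units; within the scatter) from compound 1 to compound 2 and a 2.6-fold lower number (0.41 log units; beyond the scatter) from compound 3 to compound 4, 1.4-fold (0.13 log units) apart, within the scatter of two such steps

On these data alone, whether a longer chain at this place lowers the number further remains open. So does whether an amine on the chain would be tolerated here.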